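The source may hold more compounds than are shown below. What is called first, only, known or untested is meant among the compounds shown, and "the series" means these compounds.

Measured compounds:
compound 1, `O=C(O)CCc1ccc(C#Cc2ccc(Cl)nc2)cc1`: 98%
compound 2, `O=C(O)CCc1ccc(C#Cc2cccnc2)cc1`: 96%

Both values come from an in vitro functional assay on 1321-N1 cells for agonist activity at Free fatty acid receptor 1 (Homo sapiens), read by fluorescence, spectrophotometry and calcium flux; on this read-out higher numbers stand for larger maximal responses and lower numbers for smaller maximal responses. Within the data shown here, on these two numbers compound 2 stands lowest, with compound 1 as its only neighbour just above it, and the two lie within the scatter of each other. Among the measured compounds shown here, the single measured step, a number 2 percentage points lower from compound 1 to compound 2 (within the scatter), comes from hydrogen in place of chloro on an aromatic carbon and does not leave the scatter.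

Compound 3, `Cc1ccsc1C#Cc1ccc(CCC(=O)O)cc1`, is reached from compound 2 by 3-methylthiophen-2-yl in place of pyridin-3-yl on a triple-bonded carbon. For the measured compounds named here, no measured step exchanges one ring for another, so nothing bears directly on this change; the one step known only shows that altering the ring at the triple-bonded carbon left the maximal response unchanged. On that basis a step of a number 2 percentage points lower from compound 2 to compound 3 (within the scatter) is expected, that is, none beyond the scatter. Compound 3 is therefore estimated at 94%, within a range of 78% to 108%.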

Compound 3, largest response reached (reported as efficacy), in percent of the reference or control that the assay uses: 100%
Estimate against measurement, compound 3: 6 percentage points below, and the stated range covers the measured number.
By their numbers in this assay, from the lowest: compounds 2, 1 and 3 (each within the scatter of the next).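

Exchanging the six-membered pyridin-3-yl for the five-membered 3-methylthiophen-2-yl, with sulfur as the ring hetero atom instead of nitrogen, gives in this assay a number 4 percentage points higher from compound 2 to compound 3 (within the scatter). The earlier pair changed only a chloro group on the ring, whereas this step replaces the whole ring on the triple-bonded carbon and the maximal response still stays within the scatter, so this position tolerates a change of ring size and hetero atom in these compounds. Nothing available here explains why the response holds across this exchange.

On these data alone, it remains open whether a saturated cyclohexyl group or an open butyl chain on the triple-bonded carbon would keep this response. The methyl group's share in the result is also unsettled, since plain thiophen-2-yl is not among the compounds shown.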